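Rat plasma half-life in an ester series: compound 4 outlook

This account rests on a few compounds, and the source may have more. Where it says the series, first, only, none or still open, it means among the compounds named here.

Measured so far in an ADME assay on a cell-free system (plasma, Homo sapiens) for metabolic stability, with Plasma (Rattus norvegicus) as the target, read by HPLC, at pH 7.4; on this read-out lower numbers stand for a shorter-lived compound and higher numbers for a longer-lived compound:
Compound 1 `CC(=O)Oc1ccccc1C(=O)O[C@H]1CO[C@H]2[C@@H]1OC[C@H]2OC(=O)c1ccccc1C` gives 0.0138 h.
Compound 2 `CC(=O)Oc1ccccc1C(=O)O[C@H]1CO[C@H]2[C@@H]1OC[C@H]2OC(=O)c1cccc(C)c1` gives 0.0203 h.
Compound 3 `CC(=O)Oc1ccccc1C(=O)O[C@H]1CO[C@H]2[C@@H]1OC[C@H]2OC(=O)c1ccccc1OC(=O)c1ccccc1` gives 0.0722 h.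

Compound 2 holds the second highest of the three numbers in this assay. Its closest partner is compound 1, and a 1.5-fold higher number from compound 1 to compound 2 (0.17 log units; within the scatter) is within the scatter. Going by the values given here, compound 3 sits furthest away; the one step that clears the scatter, a 5.2-fold higher number from compound 1 to compound 3 (0.72 log units; beyond the scatter), brings in a benzoyloxy group that compound 4 does not carry.

Compound 4 `CC(=O)Oc1ccccc1C(=O)O[C@H]1CO[C@H]2[C@@H]1OC[C@H]2OC(=O)c1ccncc1` differs from compound 2 by pyridin-4-yl in place of 3-methylphenyl on a carbonyl carbon. Among the compounds with values here, the only measured step that swaps one aryl ring on this carbonyl carbon for another, a 1.5-fold higher number from compound 1 to compound 2 (0.17 log units; within the scatter), stayed within the scatter. Within the data shown here, no measured pair exchanges an all-carbon ring for one with a ring nitrogen, so there is no direct guide. On this basis no step beyond the scatter is expected, so a 1.0-fold lower number from compound 2 to compound 4 (0.01 log units; within the scatter) is the estimate.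

Compound 4 is therefore expected to give 0.02 h in this assay, with a range from 0.008 h to 0.05 h.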

Compound 4, half-life: 0.0055 h
The estimate for compound 4 lay 3.6-fold (0.56 log units) above the measured number; measured number outside the range, below it.
By their numbers in this assay, from the lowest: compound 4; then compounds 1 and 2 (each within the scatter of the next); then compound 3.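

At the carbonyl carbon, the aryl ring is not freely exchangeable in this assay: pyridin-4-yl gives a 3.7-fold lower number from compound 2 to compound 4 (0.57 log units; beyond the scatter) and a 2.5-fold lower number from compound 1 to compound 4 (0.40 log units; beyond the scatter), whereas exchanging 2-methylphenyl for 3-methylphenyl gave only a 1.5-fold higher number from compound 1 to compound 2 (0.17 log units; within the scatter). Going by these compounds alone, this is the first change to give a shorter half-life beyond the scatter. No available data explain the step.

The change adds a ring nitrogen and removes the methyl, so the contribution of each remains unresolved. A plain phenyl ring at the same carbonyl carbon would separate the two.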